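The source may hold more compounds than are shown below. What is called first, only, known or untested is meant among the compounds shown, and "the series" means these compounds.

Measured compounds:
compound 1 `Cc1nn(C)c(Oc2ccc(F)cc2F)c1/C=N\CCCCCCOc1cc2oc(=O)cc(C)c2cc1Cl`: > 25000 nM
compound 2 `Cc1nn(C)c(Oc2ccccc2Br)c1/C=N\CCCCCCOc1cc2oc(=O)cc(C)c2cc1Cl`: 21800 nM

In a functional assay on U-87MG ATCC cells for antiproliferative activity against U-87 MG (Homo sapiens), read by MTT assay, with a stated time of 72 h (on this read-out lower numbers stand for stronger inhibition and higher numbers for weaker inhibition), compound 1 gives > 25000 nM, which is a limit of the assay rather than a number. Compound 2 gives 21800 nM, the only number shown here. The step of an at least 1.1-fold lower number from compound 1 to compound 2 (0.05 log units; that floor lies within the scatter) has a floor that lies within the scatter. Compound 3 `Cc1ccc(Oc2c(/C=N\CCCCCCOc3cc4oc(=O)cc(C)c4cc3Cl)c(C)nn2C)cc1` differs from compound 2 by 4-methylphenyl in place of 2-bromophenyl on an oxygen on an aromatic ring. For the measured compounds named here, only that one measured step bears on such a change, and it was small, so no step beyond the scatter is expected in this assay. Compound 3 is therefore estimated at 22000 nM, between 8000 nM and 60000 nM, a step of a 1.0-fold higher number from compound 2 to compound 3 (0.00 log units; within the scatter).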

Compound 3, half-maximal inhibitory concentration: 23600 nM
Compound 3: the middle estimate sits 1.1-fold (0.03 log units) below what was measured, within the range that was stated.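

Swapping 2-bromophenyl for 4-methylphenyl on this oxygen gives, in this assay, a 1.1-fold higher number from compound 2 to compound 3 (0.03 log units; within the scatter). For the compounds shown here, this is the first pair with a measured number at both ends, and it shows that this change of ring substituent leaves the read-out within the scatter. The step from the 2,4-difluorophenyl compound reads an at least 1.0-fold lower number from compound 1 to compound 3 (0.02 log units; that floor lies within the scatter), a floor only, because one end of it is a limit of the assay: the limit of > 25000 nM in this assay, at which 1 of the 3 values shown sits.

Going by these compounds, whether a phenyl ring carrying an amine or a carboxylic acid, or a longer chain, would bring a real change in the number stays open.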